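Nitro in place of fluoro: from compound 2 to compound 4

A few compounds are considered here, and "the series" means these few. Any claim that something is new, unique, unknown or untested is made for them only; others in the source may bear on it.

Compound 1 `CCCCNC(=O)N1CC1C#N`: > 12000 nM
Compound 2 `N#CC1CN1C(=O)Nc1ccc(F)cc1`: 2700 nM
Compound 3 `N#CC1CN1C(=O)Nc1ccc(Cl)cc1Cl`: 350 nM

Of the compounds shown here, three built on one shared core have been measured in a functional assay on MCF7 cells (Homo sapiens) for inhibition; a higher number here means a weaker inhibitor, a lower number a stronger inhibitor. For compound 1 this assay reports only a limit, (the limit of > 12000 nM in this assay, at which 1 of the 3 values shown sits), and no number. Of the two numbers that remain, compound 2 holds the higher one, with a half-maximal inhibitory concentration of 2700 nM. Compound 3, carrying two chloro groups on the same ring, gives 350 nM, a value that lies well beyond the scatter below that of compound 2.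

The step considered here leads from compound 2 to compound 4 `N#CC1CN1C(=O)Nc1ccc([N+](=O)[O-])cc1`. The change is nitro in place of fluoro on an aromatic carbon, para to the group of 8 heavy atoms. Among the compounds with values here, no step between measured compounds isolates this exchange, so the expectation rests on the two numbers above. The step from compound 2 to compound 4 is expected to go downward, by a modest amount that may only just clear the scatter, estimated as a 1.8-fold lower number from compound 2 to compound 4 (0.26 log units; within the scatter). On that basis compound 4 is expected to give about 1500 nM in this assay, within a range from 400 nM to 5000 nM.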

Compound 4, half-maximal inhibitory concentration: 3000 nM
Compound 4: middle estimate off by 2.0-fold (0.30 log units), on the low side, within the range that was stated.
By their numbers in this assay, from the lowest: compound 3; then compounds 2 and 4 (each within the scatter of the next). At a limit, above all of these: compound 1.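

Nitro in place of fluoro on an aromatic carbon, para to a group of 8 heavy atoms, is the first exchange in this set that can be read at a single place, and in this assay it amounts to a 1.1-fold higher number from compound 2 to compound 4 (0.05 log units; within the scatter). Compound 2 and compound 4 therefore cannot be told apart in this read-out, even though the entering nitro has more heavy atoms than the leaving fluoro and carries hydrogen-bond acceptors that the fluoro does not. No measurement shown here offers a reason for this outcome.

Going by these compounds, it remains open whether this flat result extends beyond these two groups, and an amine, a methoxy group or a carboxylic acid on the same aromatic carbon would test that in this assay. On these data alone, compound 3 differs from compound 2 in more than one place, so the contribution of each of its two chloro groups also remains open, and a compound with a single chloro in place of the fluoro would begin to separate them.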